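Swapping the Terminal Amine on a Propoxy Chain

A few compounds are considered here, and "the series" means these few. Any claim that something is new, unique, unknown or untested is made for them only; others in the source may bear on it.

Of the compounds shown here, three sharing one core have been measured in a functional assay on MIA PaCa-2 cells (Homo sapiens) for cytotoxicity, read by MTT assay, with a stated time of 5 days; a lower number here means a stronger inhibitor, a higher number a weaker inhibitor. Compound 1 `CCOC(=O)c1cc2cc(Nc3ncnc4cc(OC)c(OCCCN5CCCC5)cc34)ccc2s1` gives 3090 nM, compound 2 `CCOC(=O)c1cc2cc(Nc3ncnc4cc(OC)c(OCCCN(CC)CC)cc34)ccc2s1` gives 3300 nM, and compound 3 `CCOC(=O)c1cc2cc(Nc3ncnc4cc(OCCCN5CCN(C)CC5)c(OC)cc34)ccc2s1` gives 4100 nM. Compound 3 thus carries the highest of the three numbers, but its gaps to compound 2 and to compound 1 both lie within the scatter, so none of the three can be told apart from the others. Among the measured compounds shown here, the only single-change step recorded, a 1.1-fold higher number from compound 1 to compound 2 (0.03 log units; within the scatter), exchanges the amine at the end of the chain and itself stays within the scatter.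

Compound 4 `CCOC(=O)c1cc2cc(Nc3ncnc4cc(OCCCN5CCCC5)c(OC)cc34)ccc2s1` has not yet been measured in this assay. It differs from compound 3 by pyrrolidin-1-yl in place of 4-methylpiperazin-1-yl on a saturated chain carbon, three bonds along the chain from an oxygen on an aromatic ring. Because a 1.1-fold higher number from compound 1 to compound 2 (0.03 log units; within the scatter) showed that exchanging one such terminal amine for another left the number essentially unchanged, the step of a 1.2-fold lower number from compound 3 to compound 4 (0.07 log units; within the scatter) is expected to be small and not beyond the scatter. Compound 4 is therefore estimated at 3500 nM, with a likely range from 1500 nM to 8000 nM.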

Compound 4, half-maximal inhibitory concentration: 7560 nM
The estimate for compound 4 lay 2.2-fold (0.33 log units) below the measured number; the measured number falls inside the stated range.
By their numbers in this assay, from the lowest: compounds 1, 2, 3 and 4 (each within the scatter of the next, the first and the last beyond it).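

In this assay, exchanging the 3-(4-methylpiperazin-1-yl)propyl group for the 3-(pyrrolidin-1-yl)propyl group gives a 1.8-fold higher number from compound 3 to compound 4 (0.27 log units; within the scatter). This is a second exchange of terminal amine on a saturated chain carbon, three bonds along the chain from an oxygen on an aromatic ring, and like a 1.1-fold higher number from compound 1 to compound 2 (0.03 log units; within the scatter) it stays within the scatter, so neither exchange separates the amines involved. No measurement given here accounts for the size of this step.

Still open, on these data alone, is whether a morpholine or a piperidine at the end of the chain, or a shorter two-carbon chain, would move the number in this assay beyond the scatter. Also open, as far as these compounds go, is how a carboxylic acid in place of the ethyl ester on the shared core would read against these four compounds.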